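Adding a second chloro to a fused core

The compounds below may be only part of what the source reports. "The series", "measured", "known", "first", "only" and "open" are said of these compounds alone.

Measured so far:
compound 1 `ClCc1cccc(Cn2cnc3ncnc(Cl)c32)c1`, 4460 nM
compound 2 `ClCc1ccc(Cn2cnc3c(Cl)nc(Cl)nc32)cc1`, 4900 nM

In a functional assay on NCI-H460 cells (Homo sapiens) for cytotoxicity, read by sulforhodamine B assay, with a stated time of 48 h (a higher number here means a weaker inhibitor of growth, a lower number a stronger inhibitor of growth), compound 1 gives 4460 nM. Compound 2 gives 4900 nM in this assay, and the two numbers sit within the scatter of each other, so neither stands apart. Compound 3 `ClCc1cccc(Cn2cnc3nc(Cl)nc(Cl)c32)c1` has not yet been measured. Compared with compound 1 it carries chloro in place of hydrogen on an aromatic carbon. Within the data shown here, no measured pair shows this change on its own, so the size of the step is open. The step from compound 1 to compound 3 is expected to be small, a 1.1-fold higher number from compound 1 to compound 3 (0.05 log units; within the scatter), not beyond the scatter. Compound 3 is thus estimated at 5000 nM, with a range from 2000 nM to 12000 nM.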

Compound 3, concentration for total growth inhibition: 3090 nM
The estimate for compound 3 lay 1.6-fold (0.21 log units) above the measured number; low and high end bracket the measured number.
By their numbers in this assay, from the lowest: compounds 3, 1 and 2 (each within the scatter of the next).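

Chloro in place of hydrogen on this aromatic carbon, between two ring nitrogen atoms, now has a measured size in this assay (a 1.4-fold lower number from compound 1 to compound 3 (0.16 log units; within the scatter)). This single pair therefore shows that the position accepts a chloro without a change that can be told apart from the scatter. No evidence bears on this result.

As far as these compounds go, whether an amine or a methoxy group on this same carbon would move the number beyond the scatter stays open. So does whether the chloro step would look the same in another cell line.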